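Dimethylaminopropoxy replacing propyl on the chain of compound 1

This account rests on a few compounds, and the source may have more. Where it says the series, first, only, none or still open, it means among the compounds named here.

Compound 1 `CCCCc1c(F)c(N)c2c(=O)cc(-c3ccc(N)c(F)c3)oc2c1F` carries a butyl chain on the shared core; in a functional assay on MCF7 cells (Homo sapiens) for cytotoxicity, read by neutral red uptake, with a stated time of 3 days (a higher number here means a weaker inhibitor, a lower number a stronger inhibitor), compound 1 gives 8800 nM, the highest of the two numbers in hand. Among the compounds with values here, compound 2 `CN(C)c1c(F)c(N)c2c(=O)cc(-c3ccc(N)c(F)c3)oc2c1F`, with dimethylamino in place of butyl on an aromatic carbon, gives 39 nM in this assay, so the one measured step is a 230-fold lower number from compound 1 to compound 2 (2.35 log units; beyond the scatter).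

Compound 3 `CN(C)CCCOCc1c(F)c(N)c2c(=O)cc(-c3ccc(N)c(F)c3)oc2c1F` is the next variation of compound 1: 3-(dimethylamino)propoxy in place of propyl on a saturated chain carbon bound to an aromatic carbon. The saturated chain carbon bound to the aromatic carbon is kept, and the dimethylamino that in compound 2 sits directly on an aromatic carbon is here part of the 3-(dimethylamino)propoxy group.

Within the data shown here, only the step from compound 1 to compound 2 bears on this change, and only loosely: the same dimethylamino enters, but not at the same place, and a chain remains. A lower number than for compound 1 is therefore expected in this assay, though a smaller step than the one seen; the expected step is a 5.9-fold lower number from compound 1 to compound 3 (0.77 log units; beyond the scatter). For compound 3 the estimate in this assay is 1500 nM, with a range from 300 nM to 6000 nM.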

Compound 3, half-maximal inhibitory concentration: > 10000 nM
Compound 3 ended at the assay's limit; the forecaster's own chance of this, stated with the estimate: 5%; middle value at least 6.6-fold (0.82 log units) away from the limit.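

Compound 3 gives a limit of the assay, not a number, in this assay: the limit of > 10000 nM in this assay, at which 1 of the 3 values shown sits. The step is therefore only a floor, an at least 1.1-fold higher number from compound 1 to compound 3 (0.05 log units; that floor lies within the scatter), and this floor shows that adding 3-(dimethylamino)propoxy in place of propyl on a saturated chain carbon bound to an aromatic carbon does not bring the lower number that the estimate expected. The second step is an at least 250-fold higher number from compound 2 to compound 3 (2.40 log units; beyond the scatter), so in this pair a dimethylamino carried on the chain does not keep the low number seen when it sits directly on an aromatic carbon.

Still open, from the compounds shown here alone, is whether a shorter (dimethylamino)methyl group, or a chain ending in a morpholine or a primary amine, would read like compound 2 or like compound 3, and whether the oxygen of the propoxy or the length of the chain matters more, as the change from propyl alters both together. Also open, going by these compounds, is how far the true value of compound 3 lies past the limit, and so whether compound 3 differs from compound 1 at all beyond the scatter.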